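The compounds below may be only part of what the source reports. "The series", "measured", "known", "first", "only" and "open" are said of these compounds alone.

In a functional assay on MKN-45 cells (Homo sapiens) for cytotoxicity, read by MTT assay, with a stated time of 72 h (a lower number here means a stronger inhibitor, a higher number a weaker inhibitor), compound 1 `CN(C)CCn1cnnc1-c1cc(Oc2ccc(NC(=O)N/N=C/c3cccc(Br)c3)cc2F)ccn1` gives 450 nM. Compound 2 `CN(C)CCn1cnnc1-c1cc(Oc2ccc(NC(=O)N/N=C/c3c(O)ccc4ccccc34)cc2F)ccn1` gives 2020 nM. Compound 3 `CN(C)CCn1cnnc1-c1cc(Oc2ccc(NC(=O)N/N=C/c3ccccc3O[N+](=O)[O-])cc2F)ccn1` gives 1020 nM.

Compound 3 therefore stands second highest of the three numbers, with compound 2 nearest and compound 1 furthest, the latter gap being a 2.3-fold higher number from compound 1 to compound 3 (0.36 log units; beyond the scatter). Compound 4 `Cc1cc(/C=N/NC(=O)Nc2ccc(Oc3ccnc(-c4nncn4CCN(C)C)c3)c(F)c2)cc(C)c1O` differs from compound 3 only at the carbon with a double bond to nitrogen: 4-hydroxy-3,5-dimethylphenyl in place of 2-(nitrooxy)phenyl on a carbon with a double bond to nitrogen. Going by the values given here, the steps that bear on this position are a 4.5-fold higher number from compound 1 to compound 2 (0.65 log units; beyond the scatter) and a 2.0-fold lower number from compound 2 to compound 3 (0.30 log units; within the scatter), both exchanges of the aryl group at that carbon, one modest and one within the scatter. A step of at most modest size is expected in this assay, leaning toward a higher number because compound 2 with a hydroxy group on its aryl gives 2020 nM. Compound 4 is estimated at 1300 nM (range 500 nM to 3200 nM), which would be an expected 1.3-fold higher number from compound 3 to compound 4 (0.11 log units; within the scatter).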

Compound 4, half-maximal inhibitory concentration: 1510 nM
Estimate against measurement, compound 4: 1.2-fold (0.07 log units) below, and the stated range covers the measured number.
By their numbers in this assay, from the lowest: compound 1; then compounds 3, 4 and 2 (each within the scatter of the next).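

In this assay, 4-hydroxy-3,5-dimethylphenyl on the carbon with a double bond to nitrogen falls level with both 2-(nitrooxy)phenyl (a 1.5-fold higher number from compound 3 to compound 4 (0.17 log units; within the scatter)) and 2-hydroxynaphthalen-1-yl (a 1.3-fold lower number from compound 2 to compound 4 (0.13 log units; within the scatter)), but stays apart from 3-bromophenyl (a 3.4-fold higher number from compound 1 to compound 4 (0.53 log units; beyond the scatter)). Among these four compounds, compound 1 alone therefore separates, while compounds 2, 3 and 4 stay together despite their different aryl groups. Nothing given here explains these numbers.

From the compounds shown here alone, whether the separation of compound 1 belongs to its bromine remains open. A 3-chlorophenyl or 3-aminophenyl group at this carbon would test that.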